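Benzoate ester series, anilide in place of methylamide

This account rests on a few compounds, and the source may have more. Where it says the series, first, only, none or still open, it means among the compounds named here.

Measured so far:
compound 1, `CC(=O)Oc1ccc(-c2ccc(F)cc2F)cc1C(=O)Nc1ccccc1` — 8.9%
compound 2, `CNC(=O)c1cc(-c2ccc(F)cc2F)ccc1OC(=O)c1ccccc1` — 47.5%

The two measured compounds were tested in a functional assay on the whole organism (strain Kunming) for inhibition, with Mus musculus as the target, in the writhing test, at a dose of 40 mg/kg by the oral route; a lower number here means less inhibition, a higher number more inhibition at the dose given (going by the name of the read-out). Compound 2 stands highest of the two numbers, and the nearest value, that of compound 1, lies well below it, beyond the usual scatter. Compound 1 and compound 2 differ in two places at once, so the numbers give no way to tell which of the two changes carries the gap.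

Compound 3, `O=C(Oc1ccc(-c2ccc(F)cc2F)cc1C(=O)Nc1ccccc1)c1ccccc1`, has not yet been measured in this assay. Compared with compound 2 the change is phenyl in place of methyl on an amide-type nitrogen, leaving the benzoate ester of compound 2 in place. Compound 3 shares its phenylcarbamoyl group with compound 1 and its benzoate with compound 2. Going by the values given here, no single-change step in this set shows the effect of the amide substituent on its own, so the expected direction is uncertain. The step from compound 2 to compound 3 is estimated as a number 12.5 percentage points lower from compound 2 to compound 3 (beyond the scatter), a modest fall. Compound 3 is accordingly expected to give about 35%, within a range from 15% to 55%.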

Compound 3, a percentage reported as inhibition, in the whole organism at one dose (the size of the read-out at that dose, not a potency): 5.57%
Estimate against measurement, compound 3: 29.4 percentage points above; measured number below the stated range.
By their numbers in this assay, from the lowest: compounds 3 and 1 (each within the scatter of the next); then compound 2.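

Going by these compounds alone, on the benzoate ester, phenyl in place of methyl on an amide-type nitrogen gives a number 41.9 percentage points lower from compound 2 to compound 3 (beyond the scatter) in this assay, the only single-change reading of the amide substituent in this set, and it shows that the methylcarbamoyl to phenylcarbamoyl change alone is enough to carry a large step. With the phenylcarbamoyl group held constant, phenyl in place of methyl on a carbonyl carbon gives a number 3.3 percentage points lower from compound 1 to compound 3 (within the scatter) in this assay, so of the two places that separate compound 1 from compound 2, only the amide nitrogen shows a step beyond the scatter in these readings. Nothing measured here accounts for the size of the step at the amide nitrogen.

The compounds shown leave open how the read-out runs between methyl and phenyl on that nitrogen, for example with an ethyl or a benzyl group there. They also leave open whether the ester change, read here only with the phenylcarbamoyl group in place, would give the same result with the methylcarbamoyl group.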